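Lengthening the chain of compound 1

A few compounds are considered here, and "the series" means these few. Any claim that something is new, unique, unknown or untested is made for them only; others in the source may bear on it.

Measured in a functional assay on HCT-116 cells (Homo sapiens) for antiproliferative activity, read by MTT assay, with a stated time of 48 h (on this read-out lower numbers stand for stronger inhibition and higher numbers for weaker inhibition), as follows:
- compound 1 `CCCCCCCC(CCO)n1cnc2c(OC)ncnc21` gives 15300 nM
- compound 2 `CCCCCCCC(CCO)n1cnc2c(N(C)C)ncnc21` gives > 50000 nM, which is a limit of the assay and not a number

Among the measured compounds shown here, compound 1 holds the only true number so far, and its one neighbour stands at a limit. Compound 3 `CCCCCCCCCCCC(CCO)n1cnc2c(OC)ncnc21` keeps the core of compound 1 and differs on the chain only: butyl in place of hydrogen on a saturated chain carbon, eight bonds along the chain from an aromatic nitrogen. For the measured compounds named here, the one measured step is an at least 3.2-fold higher number from compound 1 to compound 2 (0.51 log units; beyond the scatter). That step lies on an aromatic carbon, not on the chain, so it shows only that the series can move and gives no direct guide here. With compound 1 at 15300 nM there is room toward lower numbers in this assay, and a modest move that way is tentatively expected. The expected step is a 2.2-fold lower number from compound 1 to compound 3 (0.34 log units; beyond the scatter). The estimated value for compound 3 is 7000 nM, with an expected range of 2000 nM to 25000 nM.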

Compound 3, half-maximal inhibitory concentration: 8230 nM
Compound 3: the middle estimate sits 1.2-fold (0.07 log units) below what was measured; measured number inside the range.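

In this assay the chain now has a reading of its own: the step is a 1.9-fold lower number from compound 1 to compound 3 (0.27 log units; within the scatter), for butyl in place of hydrogen on a saturated chain carbon, eight bonds along the chain from an aromatic nitrogen. On this read-out the two compounds cannot be told apart, so adding the butyl shifts the number by no more than repeated measurement would. Among the compounds shown here, the only earlier step lay on an aromatic carbon and left the chain untested; the chain now has one reading, and it shows this lengthening to be tolerated.

As far as these compounds go, whether a still longer chain, or an amine or a carboxylic acid on the chain, would move the number beyond the scatter stays open. Any reading of dimethylamino on the longer chain would also have to start from compound 2, whose value is a limit of the assay and not a number: the limit of > 50000 nM in this assay, at which 1 of the 3 values shown sits.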